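The source may hold more compounds than are shown below. What is called first, only, known or untested is meant among the compounds shown, and "the series" means these compounds.

Compound 1 `S=C(Nc1ccccc1)C1(c2ccccn2)CCCS1`, compound 2 `S=C(NCc1ccccc1)C1(c2ccccn2)CCCS1` and compound 3 `C=CCNC(=S)C1(c2ccccn2)CCCS1` share one core and differ only in the group on an amide-type nitrogen. In a functional assay on the whole organism (stomach) with Rattus norvegicus as the target (a lower number here means that less compound is needed, a higher number that more compound is needed for the effect), compound 1 gives > 30 mg/kg, which is a limit and not a number. In this assay compound 2 gives <= 30 mg/kg, which is also a limit. In this assay compound 3 gives > 30 mg/kg, again a limit. This places compound 3 at the limit of > 30 mg/kg in this assay, at which 2 of the 3 values shown sit.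

The next structure is compound 4 `CN(C)C(=S)C1(c2ccccn2)CCCS1`, and the change is dimethylamino in place of allylamino on a thiocarbonyl carbon. Among the measured compounds shown here, no measured step makes this exact swap. The closest evidence comes from three changes at the same nitrogen: a number no higher from compound 1 to compound 2 (the limit leaves the size open), a step that the two limits leave unreadable from compound 1 to compound 3 and a number no lower from compound 2 to compound 3 (the limit leaves the size open). None of these has a size that can be read, so they give no firm guide to direction or magnitude.

The expectation therefore leans on compound 3, whose > 30 mg/kg is a limit. No step beyond the usual scatter is expected in this assay, in either direction. The estimated change is a step that the limit leaves unreadable from compound 3 to compound 4. For compound 4 the expected value is 35 mg/kg, with an estimated range from 12 mg/kg to 100 mg/kg.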

Compound 4, dose for half-maximal effect: < 30 mg/kg
Compound 4: a limit, no number; the forecaster's own chance of this, stated with the estimate: 65%; middle value at least 1.1-fold (0.06 log units) from the limit.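

In this assay the swap of allylamino for dimethylamino gives a number no higher from compound 3 to compound 4 (the limit leaves the size open); both values are limits, so the direction of this step can be read but its size cannot. This is the first change shown that removes the hydrogen-bond donor from the group on the thiocarbonyl carbon, since allylamino carries one and dimethylamino carries none, so a hydrogen on this nitrogen is not needed for a compound to fall on the lower side of the limit. Compound 4 also sits at a limit of its own: the limit of < 30 mg/kg in this assay, at which 1 of the 4 values shown sits.

Among the compounds shown here, every value shown is a limit, so the sizes of all the steps remain unreadable and no ranking of the compounds by dose can be made. Going by these compounds, it remains open whether diethylamino, a cyclic amine such as pyrrolidine or morpholine, or a longer chain on this nitrogen would stay on the lower side, and whether a carbonyl could replace the thiocarbonyl.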